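Fluoro in place of phenoxy: an expectation for solubility

A few compounds are considered here, and "the series" means these few. Any claim that something is new, unique, unknown or untested is made for them only; others in the source may bear on it.

Measured so far:
Compound 1, `O=[N+]([O-])c1cn2c(n1)OC[C@@H](NCc1ccc(OC(F)(F)F)cc1Oc1ccccc1)C2`, gives 3 ug/mL in a physicochemical assay for solubility, at pH 6.8; on this read-out higher numbers stand for higher solubility and lower numbers for lower solubility.
Compound 2, `CC(C)N(Cc1ccc(OC(F)(F)F)cc1)[C@@H]1COc2nc([N+](=O)[O-])cn2C1`, gives a value in this assay that is a limit, < 2 ug/mL.
Compound 3, `O=[N+]([O-])c1cn2c(n1)OC[C@@H](NCc1ccc(OC(F)(F)F)c(Oc3ccccc3)c1)C2`, gives a value in this assay that is likewise a limit, < 2 ug/mL.

Within the data shown here, compound 1 therefore stands as the only actual number among the three values of this assay, since the other two sit at the limit of < 2 ug/mL in this assay, at which 2 of the 3 values shown sit. Among the measured compounds shown here, no two of the measured compounds differ in a single place, so no measured step is available to calibrate a change.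

Compound 4, `O=[N+]([O-])c1cn2c(n1)OC[C@@H](NCc1ccc(OC(F)(F)F)cc1F)C2`, is obtained from compound 1 by the following change: fluoro in place of phenoxy on an aromatic carbon. For the measured compounds named here, with no measured step of this kind to lean on, the size of the change in this assay is an estimate only; a rise beyond the usual scatter is expected, and the step of a 3.3-fold higher number from compound 1 to compound 4 (0.52 log units; beyond the scatter) is what that expectation amounts to. For compound 4 the expected value in this assay is 10 ug/mL, within a range from 3 ug/mL to 40 ug/mL.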

Compound 4, solubility: 72 ug/mL
The estimate for compound 4 lay 7.2-fold (0.86 log units) below the measured number; measured number above the stated range.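

Among these compounds, this is the only measured step in the set: in this assay, fluoro in place of phenoxy on an aromatic carbon, ortho to a large group and meta to a trifluoromethoxy group, gives a 24-fold higher number from compound 1 to compound 4 (1.38 log units; beyond the scatter). The earlier compounds shown here could not isolate this position, since none of them differed from another in a single place, and the change shows that taking away the phenoxy group moves this read-out well beyond the scatter. Compound 2 and compound 3 each stand at a limit and not at a number, so no step to either can be read: the limit of < 2 ug/mL in this assay, at which 2 of the 4 values shown sit.

From the compounds shown here alone, whether the rise comes from losing the phenoxy ring or from the fluoro itself stays open, as one step cannot separate the two. The compounds shown also leave open what hydrogen, chloro or methoxy at this carbon would give.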